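The source may report more compounds than this note shows. Statements on the series, on what has been measured and on what is new or still open speak of the compounds shown alone.

Compound 1 `CO[C@@H]1C(=O)CO[C@]2(COC(C)(C)O2)[C@@]1(O)C1(C)CO1` and compound 2 `CO[C@@H]1[C@H](OC(=O)NC(=O)CCl)CO[C@]2(COC(=O)O2)[C@]1(CCCCCc1ccccc1)OC(=O)NC(=O)CCl` share a saturated oxygenated core. In a functional assay on A-431 cells (Homo sapiens) for antiproliferative activity (on this read-out lower numbers stand for stronger inhibition and higher numbers for weaker inhibition), compound 1 gives only a limit, > 500000 nM. In this assay, among the compounds with values here, compound 2 gives 2000 nM, the sole number among the values shown; the other value sits at the limit of > 500000 nM in this assay, at which 1 of the 2 values shown sits. Compound 3 `CO[C@@H]1[C@H](OC(=O)NC(=O)CCl)CO[C@]2(COC(=O)O2)[C@@]1(O)CCCCCc1ccccc1` differs from compound 2 by hydrogen in place of ((chloromethyl)carbonyl)carbamoyl on an oxygen on a saturated carbon. Within the data shown here, no measured pair isolates this change. The step from compound 2 to compound 3 is expected to be a moderate loss, a 3.0-fold higher number from compound 2 to compound 3 (0.48 log units; beyond the scatter). Compound 3 is therefore estimated at 6000 nM, within 1500 nM to 30000 nM.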

Compound 3, half-maximal inhibitory concentration: 11000 nM
Beside the measured number, compound 3's estimate is 1.8-fold (0.26 log units) below it; the measured number falls inside the stated range.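

In this assay, within the data shown here, the replacement of ((chloromethyl)carbonyl)carbamoyl by hydrogen on this oxygen gives a 5.5-fold higher number from compound 2 to compound 3 (0.74 log units; beyond the scatter), the first direct reading of this position. Compound 3, with a free hydroxy here, still gives a measured number, so this group on this oxygen is not needed for a measurable value, although its loss costs activity beyond the scatter. No available measurement bears on the cause of this step. From the compounds shown here alone, whether a simple acetyl or methyl ether on this oxygen would match compound 2 stays open. Going by these compounds, the effect of replacing the ((chloromethyl)carbonyl)carbamoyl group that remains in compound 3 also stays open.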